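A few compounds are considered here, and "the series" means these few. Any claim that something is new, unique, unknown or untested is made for them only; others in the source may bear on it.

Compound 1, `C/C(=N\Nc1nc(-c2ccccc2)cs1)c1sc(-c2ccccc2)nc1C`, gives > 100 ug/mL in a toxicity assay on THP-1 cells (Homo sapiens) for cytotoxicity, read by MTT assay (a higher number here means a weaker inhibitor of growth, a lower number a stronger inhibitor of growth), which is a limit of the assay rather than a number. Compound 2, `C/C(=N\Nc1nc(-c2ccc(Br)cc2)cs1)c1sc(-c2ccccc2)nc1C`, gives 48.9 ug/mL in this assay.

For the measured compounds named here, compound 2 thus holds the only actual number so far; the other value is a limit (the limit of > 100 ug/mL in this assay, at which 1 of the 2 values shown sits). Going by the values given here, the one measured step, an at least 2.0-fold lower number from compound 1 to compound 2 (0.31 log units; beyond the scatter), shows that bromo entering in place of hydrogen brought the number down out of the limit. Compound 3, `C/C(=N\Nc1nc(-c2ccc(C)cc2)cs1)c1sc(-c2ccccc2)nc1C`, differs from compound 2 in a different way: methyl in place of bromo on an aromatic carbon. Among the compounds with values here, no measured step covers a swap of bromo for methyl, so the only guide is that compound 2 carries a group where compound 1 carries none and compound 3 keeps a group there. In this assay compound 3 is therefore expected to sit close to compound 2, with at most a small step of a 1.4-fold higher number from compound 2 to compound 3 (0.16 log units; within the scatter), and its estimated value is 70 ug/mL, spanning 30 ug/mL to 160 ug/mL.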

Compound 3, concentration for 50% growth inhibition: > 100 ug/mL
Compound 3: no number, only a limit; the forecaster's own chance of this, stated with the estimate: 35%; at least 1.4-fold (0.15 log units) between middle value and limit.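

In this assay, replacing bromo with methyl at this place gives an at least 2.0-fold higher number from compound 2 to compound 3 (0.31 log units; beyond the scatter). The earlier step showed only that adding bromo lowered the number, which left open whether any group there would do the same; among these compounds, the 4-bromophenyl compound stands apart, whereas the 4-methylphenyl compound gives no actual number. The step between compound 1 and compound 3 cannot be read, and compound 2 remains the only compound with a number rather than a limit: the limit of > 100 ug/mL in this assay, at which 2 of the 3 values shown sit.

As far as these compounds go, how far compound 3 lies past its limit remains unknown, so methyl cannot be ranked against hydrogen. Also open, from the compounds shown here alone, is whether the lower number is particular to bromo or would also appear with chloro, fluoro, methoxy or an amine at this place.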